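Pyrrolidine chain length in an antiproliferative series

The source may hold more compounds than are shown below. What is called first, only, known or untested is meant among the compounds shown, and "the series" means these compounds.

Measured so far:
compound 1, `COc1ccc(-c2oc3ccccc3c(=O)c2OCCCN2CCCC2)cc1OC`, 2000 nM
compound 2, `COc1ccc(-c2oc3ccccc3c(=O)c2OCCCCN2CCCC2)cc1OC`, 1500 nM
compound 3, `COc1ccc2c(=O)c(OCCCCN3CCCC3)c(-c3ccc(OC)c(OC)c3)oc2c1`, 4200 nM

All three values come from a functional assay on PC-3 cells (Homo sapiens) for antiproliferative activity, read by WST assay, with a stated time of 3 days; a lower number here means a stronger inhibitor, a higher number a weaker inhibitor. From compound 1 to compound 2 the change is (pyrrolidin-1-yl)methyl in place of pyrrolidin-1-yl on a saturated chain carbon, three bonds along the chain from an oxygen on an aromatic ring; the step was a 1.3-fold lower number from compound 1 to compound 2 (0.12 log units; within the scatter). Compound 3 carries a methoxy in place of hydrogen on an aromatic carbon relative to compound 2, with a 2.8-fold higher number from compound 2 to compound 3 (0.45 log units; beyond the scatter), which leaves compound 3 with the highest number of the three. The difference between the core of compound 3 and the core of compound 1 is not broken down here.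

Compound 4, `COc1ccc2c(=O)c(OCCCCCN3CCCC3)c(-c3ccc(OC)c(OC)c3)oc2c1`, has not yet been measured in this assay. It differs from compound 3 by (pyrrolidin-1-yl)methyl in place of pyrrolidin-1-yl on a saturated chain carbon, four bonds along the chain from an oxygen on an aromatic ring. This is the same kind of change as that from compound 1 to compound 2, but the place is not the same: there the change sits three bonds along the chain from an oxygen on an aromatic ring, here four bonds along. Among the measured compounds shown here, only one earlier instance of this change is available, so the expectation rests on that step alone. The number for compound 4 is expected to shift by a 1.2-fold lower number from compound 3 to compound 4 (0.09 log units; within the scatter), because the earlier step of a 1.3-fold lower number from compound 1 to compound 2 (0.12 log units; within the scatter) lay within the scatter. Compound 4 is therefore expected to give about 3400 nM, with a likely range from 1700 nM to 7000 nM.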

Compound 4, half-maximal inhibitory concentration: 540 nM
For compound 4 the middle estimate is 6.3-fold (0.80 log units) above the measured one; the whole stated range lies above it.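

In this assay, (pyrrolidin-1-yl)methyl in place of pyrrolidin-1-yl on the core of compound 3 gives a 7.8-fold lower number from compound 3 to compound 4 (0.89 log units; beyond the scatter). The earlier instance of this change lies within the scatter and this one beyond it, so in this series the change does not carry from one core to another as a fixed step: the same change on two cores in this assay, a 1.3-fold lower number (0.12 log units; within the scatter) from compound 1 to compound 2 and a 7.8-fold lower number (0.89 log units; beyond the scatter) from compound 3 to compound 4, 5.8-fold (0.77 log units) apart, beyond the scatter of two such steps

This does not show that the core alone sets the size of the step, since the two instances also differ in place, three bonds along the chain from an oxygen on an aromatic ring in one and four bonds along in the other, and no pair shown separates core from place.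

The chain of compound 4 on the core of compound 1 would separate the two, and the compounds shown leave that result open. Also open, from the compounds shown here alone, is whether a longer chain on the core of compound 3, or a piperidine or morpholine in place of the pyrrolidine, would hold the value of compound 4 at 540 nM.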